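Swapping the amide's aryl ring for a cyclohexenyl ring

The compounds below may be only part of what the source reports. "The series", "measured", "known", "first", "only" and "open" are said of these compounds alone.

Measured so far:
compound 1 `O=C(Nc1cc(-c2ccccc2)nn1-c1ccccc1)c1ccc([N+](=O)[O-])cc1` — 10.7 nM
compound 2 `Cc1ccc(C(=O)Nc2cc(-c3ccccc3)nn2-c2ccccc2)cc1C` — 20 nM

Both compounds were tested in a functional assay on cells for positive allosteric modulation of metabotropic glutamate receptor 5 (Rattus norvegicus), read by calcium flux; a lower number here means that less compound is needed, a higher number that more compound is needed for the effect. Compound 2 holds the highest of the two numbers, but its nearest neighbour is compound 1, and the step of a 1.9-fold higher number from compound 1 to compound 2 (0.27 log units; within the scatter) lies within the scatter, so the two cannot be told apart. The unmeasured compound 3 `O=C(Nc1cc(-c2ccccc2)nn1-c1ccccc1)C1=CCCCC1` differs from compound 2 in one place: cyclohex-1-en-1-yl in place of 3,4-dimethylphenyl on a carbonyl carbon. Within the data shown here, the only measured step, from compound 1 to compound 2, exchanged one aromatic substituent pattern for another and was within the scatter; it says nothing direct about trading an aromatic ring for a non-aromatic one, so the bearing on this step is weak. Compound 3 is therefore expected to give a modestly higher number, a 2.0-fold higher number from compound 2 to compound 3 (0.30 log units; within the scatter), with wide uncertainty, estimated at 40 nM (range 10 nM to 160 nM).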

Compound 3, half-maximal effective concentration: 3300 nM
Compound 3: the middle estimate sits 83-fold (1.92 log units) below what was measured, outside the stated range (above it).
By their numbers in this assay, from the lowest: compounds 1 and 2 (each within the scatter of the next); then compound 3.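

The 3,4-dimethylphenyl and 4-nitrophenyl rings on the carbonyl carbon could not be told apart, which gave no sign that this position was demanding. In this assay the non-aromatic cyclohex-1-en-1-yl ring changes that picture, with a 170-fold higher number from compound 2 to compound 3 (2.22 log units; beyond the scatter) and a 310-fold higher number from compound 1 to compound 3 (2.49 log units; beyond the scatter), so among these three compounds the change from an aromatic ring to this non-aromatic one matters far more than the change of substituents on the aromatic ring. Nothing shown here accounts for this large rise.

The compounds shown leave open whether the high number belongs to non-aromatic rings in general or to cyclohex-1-en-1-yl alone, a question that a cyclohexyl or piperidine ring on the carbonyl carbon could address. They also leave open whether any aromatic ring would serve here, as a plain phenyl or a pyridine ring could show.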